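The source may report more compounds than this note shows. Statements on the series, on what has been measured and on what is new or still open speak of the compounds shown alone.

The compounds share a core in which a trimethoxyphenyl-bearing pyrazole is joined through a propenone to an aryl group on the carbonyl carbon. In a functional assay on SK-MEL-28 cells (Homo sapiens) for cytotoxicity, read by sulforhodamine B assay, with a stated time of 48 h, tested at 100 uM (a lower number here means a stronger effect, a higher number a weaker effect of the compound at the concentration tested), compound 1 `COc1cc(-c2cc(/C=C/C(=O)c3ccc(N)cc3)[nH]n2)cc(OC)c1OC` gives -83%. Compound 2 `COc1ccc(C(=O)/C=C/c2cc(-c3cc(OC)c(OC)c(OC)c3)n[nH]2)cc1OC`, in which a 3,4-dimethoxyphenyl replaces the 4-aminophenyl on the carbonyl carbon, gives -90% in this assay, and the two numbers lie within the scatter of each other; the step is a number 7 percentage points lower from compound 1 to compound 2 (within the scatter). Compound 3 `COc1cc(-c2cc(/C=C/C(=O)c3ccc(F)c(F)c3)[nH]n2)cc(OC)c1OC` differs from compound 2 at the same carbonyl carbon: 3,4-difluorophenyl in place of 3,4-dimethoxyphenyl on a carbonyl carbon. For the measured compounds named here, only that one measured step bears on this change, and it did not exceed the scatter, so for compound 3 in this assay no step beyond the scatter is expected, estimated as a number 5 percentage points higher from compound 2 to compound 3 (within the scatter). The estimate for compound 3 in this assay is -85%, with an expected range from -100% to -60%.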

Compound 3, a percentage reported as activity, at one concentration (the size of the read-out at that concentration, not a potency): -39%
For compound 3 the middle estimate is 46 percentage points below the measured one, and the stated range ends below it.
By their numbers in this assay, from the lowest: compounds 2 and 1 (each within the scatter of the next); then compound 3.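

The aryl group on the carbonyl carbon proves not to be a freely exchangeable position in this assay: 3,4-difluorophenyl in place of 3,4-dimethoxyphenyl gives a large step (a number 51 percentage points higher from compound 2 to compound 3 (beyond the scatter)), and in place of 4-aminophenyl it gives another (a number 44 percentage points higher from compound 1 to compound 3 (beyond the scatter)). The agreement within the scatter between compound 1 and compound 2 therefore does not extend to every aryl group, and compound 3 has the weakest effect of the three at the concentration tested. Nothing available here accounts for the difference between the 3,4-difluorophenyl group and the other two aryl groups.

The compounds shown leave open whether the weaker effect of compound 3 follows from the fluorine atoms themselves or from the absence of the methoxy or amino groups. As far as these compounds go, it also remains open whether a plain phenyl, a 3,4-dichlorophenyl or a 4-hydroxyphenyl on the carbonyl carbon would stand with compound 1 and compound 2 or with compound 3.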